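This account rests on a few compounds, and the source may have more. Where it says the series, first, only, none or still open, it means among the compounds named here.

Measured compounds:
compound 1, `CS(=O)(=O)c1ccc(Cc2nnc3n2N=C(c2cc(Cl)sc2Cl)CS3)cc1`: 47.3%
compound 2, `CS(=O)(=O)c1ccc(Cc2nnc3n2N=C(c2cc4ccccc4c(=O)o2)CS3)cc1`: 10.6%

In a functional assay on HT-29 cells (Homo sapiens) for cytotoxicity, read by MTT assay, with a stated time of 48 h, tested at 100 uM (a lower number here means a weaker effect, a higher number a stronger effect of the compound at the concentration tested), compound 1 gives 47.3%, the higher of the two numbers; compound 2 gives 10.6%, a gap beyond the usual scatter. Compound 3, `CS(=O)(=O)c1ccc(Cc2nnc3n2N=C(c2ccc(O)c(C(N)=O)c2)CS3)cc1`, has not yet been measured. It differs from compound 1 in one place: 3-carbamoyl-4-hydroxyphenyl in place of 2,5-dichlorothiophen-3-yl on a carbon with a double bond to nitrogen. Within the data shown here, no step between measured compounds is known, so the size of the change in this assay can only be expected; a downward step of moderate size is expected. Compound 3 is estimated at 22% with a range from 5% to 45%. For compound 3 the expected step is a number 25.3 percentage points lower from compound 1 to compound 3 (beyond the scatter).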

Compound 3, a percentage reported as activity, at one concentration (the size of the read-out at that concentration, not a potency): 37.1%
The estimate for compound 3 lay 15.1 percentage points below the measured number, within the range that was stated.
By their numbers in this assay, from the lowest: compound 2; then compound 3; then compound 1.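

In this assay, the position on the carbon with a double bond to nitrogen now has its first readable step: 3-carbamoyl-4-hydroxyphenyl in place of 2,5-dichlorothiophen-3-yl is a number 10.2 percentage points lower from compound 1 to compound 3 (beyond the scatter), a modest change. A read-out of this size therefore does not depend on the chlorine atoms or the five-membered aromatic ring of compound 1. Nothing available explains this step. Still open, going by these compounds, is how a plain phenyl or a phenyl bearing only a hydroxyl would compare here. On these data alone, the effect of a carboxylic acid or an amine on that ring also remains unknown.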